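A few compounds are considered here, and "the series" means these few. Any claim that something is new, unique, unknown or untested is made for them only; others in the source may bear on it.

Values in a physicochemical assay for lipophilicity, at pH 7.4 (on this read-out lower numbers stand for lower lipophilicity and higher numbers for higher lipophilicity), for the measured compounds

Compound 1 `CCS(=O)(=O)c1ccc(CN(CC(C)C)S(=O)(=O)c2ccc3c(c2)C(O)CC(C2CCOCC2)O3)nc1` gives 1.42
Compound 2 `CC(C)CN(c1ccc(C#N)cc1)S(=O)(=O)c1ccc2c(c1)C(O)CC(C1CCOCC1)O2` gives 3.07
Compound 3 `CC(C)CN(c1cc2ccccc2s1)S(=O)(=O)c1ccc2c(c1)C(O)CC(C1CCOCC1)O2` gives 3.92

Compound 3 gives 3.92 and stands highest of these three. The next structure, compound 4 `CC(C)CN(Cc1ccccc1C(F)(F)F)S(=O)(=O)c1ccc2c(c1)C(O)CC(C1CCOCC1)O2`, keeps the shared core and differs in one place, 2-(trifluoromethyl)benzyl in place of 1-benzothiophen-2-yl on a sulfonamide nitrogen which in words is 2-(trifluoromethyl)benzyl in place of 1-benzothiophen-2-yl on a sulfonamide nitrogen.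

Among the compounds with values here, all the measured steps changed this same place. The step of a number 1.65 log units higher from compound 1 to compound 2 (beyond the scatter) is large, as is a number 2.50 log units higher from compound 1 to compound 3 (beyond the scatter) in the same direction. Both start from the (5-(ethylsulfonyl)pyridin-2-yl)methyl group, which compound 4 does not carry, so the modest step of a number 0.85 log units higher from compound 2 to compound 3 (beyond the scatter) is the closer guide to the likely size. Within the data shown here, no measured compound carries the 2-(trifluoromethyl)benzyl group, so the data offer no direct precedent.

The estimated change is a number 0.22 log units lower from compound 3 to compound 4 (within the scatter) and is expected to be a slight fall that may not clear the scatter. For compound 4 the estimate is 3.7 with 3.3 to 4.1 as the expected span.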

Compound 4, distribution coefficient: 4.23
Estimate against measurement, compound 4: 0.53 log units below; the measured number lies above the stated range.
By their numbers in this assay, from the lowest: compound 1; then compound 2; then compound 3; then compound 4.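

In this assay, 2-(trifluoromethyl)benzyl on the sulfonamide nitrogen gives a number 0.31 log units higher from compound 3 to compound 4 (beyond the scatter), so this position can go higher than it did with 1-benzothiophen-2-yl, the top of the earlier series. The same group gives a number 1.16 log units higher from compound 2 to compound 4 (beyond the scatter) when it replaces 4-cyanophenyl. With the saturated chain carbon on that nitrogen kept, changing only the ring it carries gives a number 2.81 log units higher from compound 1 to compound 4 (beyond the scatter), so that carbon alone does not tie the number to either end of this range.

Nothing shown here explains why these numbers differ. From the compounds shown here alone, it also stays open how a plain benzyl group, without the trifluoromethyl, would compare, and how a benzyl group carrying an amine or a carboxylic acid would read.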